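Dibromophenyl in place of isobutoxyphenyl at the amide

The compounds below may be only part of what the source reports. "The series", "measured", "known", "first", "only" and "open" are said of these compounds alone.

compound 1, `CCCOc1ccc(NC(=O)CSc2nnc(Cc3nn(C)c(=O)c4ccccc34)n2C)cc1`: > 30000 nM
compound 2, `CC(C)COc1ccc(NC(=O)CCCCCCCSc2nnc(Cc3nn(C)c(=O)c4ccccc34)n2C)cc1`: 4800 nM
compound 3, `Cn1c(Cc2nn(C)c(=O)c3ccccc23)nnc1SCCCCCCCCCCC(=O)Nc1ccc(Cl)cc1`: 20000 nM

Of the compounds shown here, three sharing one core have been tested in an assay on isolated protein (Mus musculus) for inhibition of IL15-IL15 receptor (Homo sapiens), read by resazurin assay, with stated times of 30 min and 2.5 days; on this read-out lower numbers stand for stronger inhibition and higher numbers for weaker inhibition. Compound 1, `CCCOc1ccc(NC(=O)CSc2nnc(Cc3nn(C)c(=O)c4ccccc34)n2C)cc1`, is reported only as a limit of that assay, > 30000 nM, which is what the limit of > 30000 nM in this assay, at which 1 of the 3 values shown sits, records. Compound 2, `CC(C)COc1ccc(NC(=O)CCCCCCCSc2nnc(Cc3nn(C)c(=O)c4ccccc34)n2C)cc1`, gives 4800 nM in this assay and so holds the lowest of the two numbers actually measured. Within the data shown here, compound 3, `Cn1c(Cc2nn(C)c(=O)c3ccccc23)nnc1SCCCCCCCCCCC(=O)Nc1ccc(Cl)cc1`, gives 20000 nM in this assay, a higher number that lies beyond the scatter of the method; since compound 3 also carries a different chain and a different aryl group, no single step is known between it and compound 2.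

Compound 4, `Cn1c(Cc2nn(C)c(=O)c3ccccc23)nnc1SCCCCCCCC(=O)Nc1ccc(Br)cc1Br`, has not yet been measured. It differs from compound 2 in one place: 2,4-dibromophenyl in place of 4-(isobutoxy)phenyl on an amide-type nitrogen, in words, 2,4-dibromophenyl in place of 4-(isobutoxy)phenyl on an amide-type nitrogen. Among the measured compounds shown here, no measured pair isolates such an exchange, so the expectation rests on the bare fact that the only other halogenated aryl amide, compound 3, returned a higher number than compound 2. The author therefore expects a step from compound 2 to compound 4 of a 1.9-fold higher number from compound 2 to compound 4 (0.27 log units; within the scatter), toward weaker inhibition rather than stronger. Compound 4 is estimated at 9000 nM, with a range from 2500 nM to 30000 nM.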

Compound 4, half-maximal inhibitory concentration: 1500 nM
Compound 4: the middle estimate sits 6.0-fold (0.78 log units) above what was measured; measured number outside the range, below it.
By their numbers in this assay, from the lowest: compound 4; then compound 2; then compound 3. At a limit, above all of these: compound 1.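

With the chain of compound 2 left unchanged, placing 2,4-dibromophenyl on the amide-type nitrogen in place of 4-(isobutoxy)phenyl gives a 3.2-fold lower number from compound 2 to compound 4 (0.51 log units; beyond the scatter) in this assay. Among these compounds, this is the first step in the set that changes a single place, and it shows that inhibition at this position does not depend on 4-(isobutoxy)phenyl: the entering group has 0 hydrogen-bond acceptors against 1 for the group that leaves, has fewer heavy atoms, and still gives the lower number. Among the compounds shown here, compound 1 and compound 3 each differ from compound 4 in more than one place, so no steps to them can be read, and the higher number of compound 3 does not count against this exchange.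

Nothing in the data shown accounts for the size or direction of this step. As far as these compounds go, it remains open whether both bromines are needed, whether 2,4-dichlorophenyl or a phenyl ring bearing an amine or a carboxylic acid would serve on this nitrogen, and whether the exchange would hold on the longer chain of compound 3.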